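The compounds below may be only part of what the source reports. "The series", "measured", "known", "first", "only" and "open" are said of these compounds alone.

Measured in a functional assay on KB cells (Homo sapiens) for cytotoxicity; a higher number here means that more compound is needed for the effect, a lower number that less compound is needed:
compound 1 `COc1ccc(-c2cc(=O)c3cc(OC)c(OC)c(OC)c3o2)cc1` gives 5 ug/mL
compound 2 `COc1ccccc1-c1cc(=O)c2ccc(OC)c(OC)c2o1` gives 4 ug/mL
compound 3 `COc1cc(OC)c(-c2cc(=O)c3c(OC)c(OC)c(OC)c(OC)c3o2)cc1OC` gives 13 ug/mL

Compound 1 stands second highest of the three numbers. Its value and that of compound 2 lie within the scatter of each other, so nothing separates them. Compound 3 gives the higher number, and that gap is beyond the scatter.

Compound 4 `COc1cc2c(=O)cc(-c3ccc(O)cc3)oc2c(OC)c1OC` is not yet measured. It differs from compound 1 in one place: hydrogen in place of methyl on an oxygen on an aromatic ring. For the measured compounds named here, no step between measured compounds covers a change of methoxy to hydroxy, so the expectation rests on compound 1 alone, and the step in this assay is expected to be small, none beyond the scatter in either direction. Compound 4 is therefore estimated at 6 ug/mL, within 2 ug/mL to 16 ug/mL, and the step of a 1.2-fold higher number from compound 1 to compound 4 (0.08 log units; within the scatter) is expected to stay inside the scatter.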

Compound 4, concentration for half-maximal effect: 0.7 ug/mL
Estimate against measurement, compound 4: 8.6-fold (0.93 log units) above; measured number outside the range, below it.
By their numbers in this assay, from the lowest: compound 4; then compounds 2 and 1 (each within the scatter of the next); then compound 3.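

Methoxy to hydroxy on the 4-methoxyphenyl group is the first change in one place in this series, and in this assay it gives a 7.1-fold lower number from compound 1 to compound 4 (0.85 log units; beyond the scatter) with nothing else altered. The number at this position therefore moves with the methyl on that oxygen, and the hydroxy form needs less compound. No measurement here bears on the origin of this step.

On these data alone, whether the hydroxy itself is required stays open, since an amine, a fluorine or an ethoxy in its place would test that. Also open, as far as these compounds go, is whether the methoxy groups on the shared core respond to the same change.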